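Swapping heptyl for cyclohexyl on two related cores

This account rests on a few compounds, and the source may have more. Where it says the series, first, only, none or still open, it means among the compounds named here.

Four compounds share a bromo-bearing six-membered ring with one nitrogen, which carries a tolyl sulfonyl group, and differ in the large group sitting on the ring carbon beside that nitrogen and in whether the ring is saturated. Compound 1 `CCCCCCC[C@H]1C[C@H](Br)CCN1S(=O)(=O)c1ccc(C)cc1` carries a heptyl chain on a saturated ring. In a functional assay on SW1573 cells (Homo sapiens) for antiproliferative activity, read by sulforhodamine B assay, with a stated time of 48 h (a lower number here means a stronger inhibitor of growth, a higher number a weaker inhibitor of growth), compound 1 gives only a limit, > 100000 nM, and not a number. Compound 2 `Cc1ccc(S(=O)(=O)N2CC[C@@H](Br)C[C@@H]2C2CCCCC2)cc1` is the same core with cyclohexyl instead; in this assay compound 2 gives 82000 nM. The change from compound 1 to compound 2 is cyclohexyl in place of heptyl on a saturated ring carbon and produced an at least 1.2-fold lower number from compound 1 to compound 2 (0.08 log units; that floor lies within the scatter), a floor set by the limit of > 100000 nM in this assay, at which 1 of the 3 values shown sits.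

Compound 3 `CCCCCCCC1C=C(Br)CCN1S(=O)(=O)c1ccc(C)cc1` keeps heptyl but on a core with a double bond; in this assay compound 3 gives 49000 nM. The difference between the core of compound 1 and the core of compound 3 is not broken down here.

Compound 4 `Cc1ccc(S(=O)(=O)N2CCC(Br)=CC2C2CCCCC2)cc1` has not yet been measured. It relates to compound 3 as compound 2 relates to compound 1: the change is cyclohexyl in place of heptyl on a saturated ring carbon, the same change as before, at the same place. Since that earlier step gave only a lower bound within the scatter, compound 4 is expected to land close to compound 3, with the step from compound 3 to compound 4 estimated at a 1.2-fold lower number from compound 3 to compound 4 (0.09 log units; within the scatter). Compound 4 is therefore estimated at 40000 nM in this assay, with an expected spread from 15000 nM to 100000 nM.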

Compound 4, concentration for 50% growth inhibition: 65000 nM
For compound 4 the middle estimate is 1.6-fold (0.21 log units) below the measured one; the measured number falls inside the stated range.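

On the core with the double bond, the swap gives in this assay a 1.3-fold higher number from compound 3 to compound 4 (0.12 log units; within the scatter), so cyclohexyl and heptyl cannot be told apart on this core. Set beside the same swap on the saturated core, the comparison reads: the same change on two cores in this assay, an at least 1.2-fold lower number (0.08 log units; that floor lies within the scatter) from compound 1 to compound 2 and a 1.3-fold higher number (0.12 log units; within the scatter) from compound 3 to compound 4; the limit leaves it open whether they differ. Neither measured step stands clear of the usual scatter, so there is no shown gain or loss to carry from one core to the other, but this does not prove that the two cores respond alike, for the real step on the saturated core could be larger than its floor: the limit of > 100000 nM in this assay, at which 1 of the 4 values shown sits.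

The compounds shown leave open whether a group of a different kind on the ring carbon next to the ring nitrogen, such as an amine, a carboxylic acid or a phenyl ring, would move the number beyond the scatter, as only heptyl and cyclohexyl appear there. They also leave open what the double bond does by itself, and whether a nitrile or a chloro group in place of the bromo group would change growth inhibition on either core.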